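The source may hold more compounds than are shown below. What is called first, only, known or untested is meant among the compounds shown, and "the series" means these compounds.

Going by the values given here, compound 2 `CC(=O)N1CC(CNC(=O)c2ccncc2Nc2cc(-c3ccc4ccn(C)c4c3)c3nccnc3c2)C1` gives 137 nM in an assay for inhibition of 6-phosphofructo-2-kinase/fructose-2,6-bisphosphatase 3 (Homo sapiens), read by ADP-Glo, with a stated time of 2 h (on this read-out higher numbers stand for weaker inhibition and lower numbers for stronger inhibition), the higher of the two numbers measured so far, yet compound 1 `Cn1ccc2ccc(-c3cc(Nc4cnccc4C(=O)NCc4cncnc4)cc4nccnc34)cc21` with 106 nM lies within the scatter of it. The step of a 1.3-fold higher number from compound 1 to compound 2 (0.11 log units; within the scatter) altered the same part of the molecule that changes now. Compound 3 `CN1CCC(N(C)C(=O)c2ccncc2Nc2cc(-c3ccc4ccn(C)c4c3)c3nccnc3c2)C1` differs from compound 2 by methyl(1-methylpyrrolidin-3-yl)amino in place of ((1-acetylazetidin-3-yl)methyl)amino on a carbonyl carbon. Among the compounds with values here, since the one measured change at that place, a 1.3-fold higher number from compound 1 to compound 2 (0.11 log units; within the scatter), stayed within the scatter, the step of a 1.1-fold higher number from compound 2 to compound 3 (0.04 log units; within the scatter) is expected to be small. Compound 3 is therefore estimated at 150 nM in this assay, with a range from 60 nM to 400 nM.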

Compound 3, half-maximal inhibitory concentration: 176 nM
Estimate against measurement, compound 3: 1.2-fold (0.07 log units) below; low and high end bracket the measured number.
By their numbers in this assay, from the lowest: compounds 1, 2 and 3 (each within the scatter of the next).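

The swap on this carbonyl carbon (a 1.3-fold higher number from compound 2 to compound 3 (0.11 log units; within the scatter)) in this assay takes the group from 1 hydrogen-bond donor to 0 and replaces a four-membered non-aromatic ring with a five-membered one, yet the numbers stay within the scatter. Replacing ((pyrimidin-5-yl)methyl)amino with the same group (a 1.7-fold higher number from compound 1 to compound 3 (0.22 log units; within the scatter)) also stays within it, so three different groups here give indistinguishable numbers.

As far as these compounds go, how a carboxylic acid or a longer chain ending in a primary amine would read at this place stays open. Nothing available explains why these numbers stay so close.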